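This account rests on a few compounds, and the source may have more. Where it says the series, first, only, none or still open, it means among the compounds named here.

Working notes on the series. All numbers come from a functional assay on KYSE-450 cells (Homo sapiens) for inhibition, read by MTT assay, with a stated time of 48 h; a lower number here means a stronger inhibitor, a higher number a weaker inhibitor. Compound 1 `COc1cc(NCc2ccccc2)cc(OC)c1OC` returns no number, only a limit of the measurement, > 80000 nM; this is the limit of > 80000 nM in this assay, at which 1 of the 3 values shown sits. Compound 2 `C#CC(=O)N(Cc1ccc(OC)c(O)c1)c1cc(OC)c(OC)c(OC)c1` gives 570 nM in this assay. Compound 3 `COc1ccc(N(Cc2cc(OC)c(OC)c(OC)c2)C(=O)CN=[N+]=[N-])cc1O` gives 26100 nM in this assay. Of the two numbers on hand, compound 2 has the lowest; the nearest is compound 3, and the gap between them lies beyond the usual scatter of repeated measurements.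

Compound 4 `C/C=C/C(=O)N(Cc1ccc(OC)c(O)c1)c1cc(OC)c(OC)c(OC)c1` has not yet been measured in this assay. Set against compound 2, the change is prop-1-en-1-yl in place of ethynyl on a carbonyl carbon. Within the data shown here, no measured pair differs in just one place, so there is no measured step of comparable kind to set a scale for this one; the size of the step has to be guessed from the structures alone.

The expectation is a move toward a higher number, of a size beyond the scatter but not large, with the outcome for compound 2 as the anchor at 570 nM. Compound 4 is expected to give 1800 nM in this assay, within a range of 600 nM to 6000 nM. That estimate corresponds to an expected step of a 3.2-fold higher number from compound 2 to compound 4 (0.50 log units; beyond the scatter).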

Compound 4, half-maximal inhibitory concentration: 67 nM
Compound 4: the middle estimate sits 27-fold (1.43 log units) above what was measured; the measured number lies below the stated range.
By their numbers in this assay, from the lowest: compound 4; then compound 2; then compound 3. At a limit, above all of these: compound 1.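

In this assay, among these compounds, prop-1-en-1-yl in place of ethynyl on a carbonyl carbon gives an 8.5-fold lower number from compound 2 to compound 4 (0.93 log units; beyond the scatter), the first measured step, and it shows that this position, where the other neighbour of the carbonyl carbon is the amide-type nitrogen, responds to the group it carries. For this pair, a triple bond outside aromatic rings is not needed for a low number, as the group with a double bond and one more carbon gives the lower number of the two. Nothing on hand bears on why the step runs in this direction.

The single step changes the bond type and the carbon count together, so the compounds shown do not tell which of the two goes with the lower number; a propyl chain or a plain ethenyl group on the same carbonyl carbon would separate them. Among the compounds shown here, also open is how far this position tolerates a longer chain or a terminal amine, and whether the step from ethynyl to prop-1-en-1-yl holds on any core other than the one shared by compound 2 and compound 4.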